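Carbamoyl on the benzyl group: solubility notes

This account rests on a few compounds, and the source may have more. Where it says the series, first, only, none or still open, it means among the compounds named here.

Measured so far:
compound 1 `Cc1noc(-c2nc(C)c3c(c2N)C(=O)N(Cc2ccccc2)C3=O)n1` gives < 5000 nM in a physicochemical assay for solubility, using the shake flask method, in simulated intestinal fluid, measured as kinetic solubility, with a stated time of 2 h, at 25 degrees C, at pH 6.5 (a higher number here means a more soluble compound, a lower number a less soluble compound), a limit only.
compound 2 `Cc1noc(-c2nc(C)c3c(c2N)C(=O)N(Cc2ccc(F)cc2)C3=O)n1` gives < 5000 nM in this assay, a limit only.
compound 3 `Cc1noc(-c2nc(C)c3c(c2N)C(=O)N(Cc2ccccc2Cl)C3=O)n1` gives < 5000 nM in this assay, a limit only.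

Compound 1 stands at a limit of this assay and nowhere on a number. Every other value shown sits at the same point, (the limit of < 5000 nM in this assay, at which 3 of the 3 values shown sit), so a step that the two limits leave unreadable from compound 1 to compound 2, a step that the two limits leave unreadable from compound 1 to compound 3 and a step that the two limits leave unreadable from compound 2 to compound 3 cannot be read. Compound 4 `Cc1noc(-c2nc(C)c3c(c2N)C(=O)N(Cc2ccc(C(N)=O)cc2)C3=O)n1` differs from compound 1 by carbamoyl in place of hydrogen on an aromatic carbon. Within the data shown here, none of the measured steps speaks readably to this change, and no direction beyond the scatter follows from them. Compound 4 is estimated at 6000 nM, between 1500 nM and 40000 nM. The step this estimate means, an at least 1.2-fold higher number from compound 1 to compound 4 (0.07 log units; that floor lies within the scatter), is expected to be modest, and a further limit rather than a number is a real possibility.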

Compound 4, solubility: < 5000 nM
Compound 4: no number, only a limit; the forecaster's own chance of this, stated with the estimate: 45%; middle value at least 1.2-fold (0.07 log units) away from the limit.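

Compound 4 gives only a limit in this assay, as do compound 1, compound 2 and compound 3, so no step among them can be read: the limit of < 5000 nM in this assay, at which 4 of the 4 values shown sit.

The compounds shown leave open whether carbamoyl in place of hydrogen on an aromatic carbon shifts solubility at all.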